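Removing One Trifluoromethyl Group From a Urea Side Chain

The compounds below may be only part of what the source reports. "The series", "measured", "known", "first", "only" and "open" are said of these compounds alone.

Measured compounds:
Compound 1, `O=C(Nc1cccc(-n2cc(-c3ccncc3)c(-c3cc(O)cc(Cl)c3)n2)c1)Nc1ccc(Cl)c(C(F)(F)F)c1`, gives 83%.
Compound 2, `COc1cc(Cl)cc(-c2nn(-c3cccc(NC(=O)Nc4cc(C(F)(F)F)cc(C(F)(F)F)c4)c3)cc2-c2ccncc2)c1`, gives 25%.

Both values come from a functional assay on M14 cells (Homo sapiens) for inhibition, read by sulforhodamine B assay, with a stated time of 48 h, tested at 1 uM; a higher number here means a weaker effect of the compound at the concentration tested, a lower number a stronger effect. Compound 2 stands lowest of the two numbers, so its effect is the stronger one; compound 1 lies well above it, and that gap is beyond the usual scatter. Within the data shown here, no pair of these two differs in only one place, so the two values show only that the two molecules behave very differently.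

Compound 3, `COc1cc(Cl)cc(-c2nn(-c3cccc(NC(=O)Nc4cccc(C(F)(F)F)c4)c3)cc2-c2ccncc2)c1`, has not yet been measured in this assay. It differs from compound 2 as follows: hydrogen in place of trifluoromethyl on an aromatic carbon. Removing one trifluoromethyl group, and nothing more, is a small change, and the data give no direct guide to its effect. A moderate weakening is expected, since compound 2 stands at 25% with two such groups. The step from compound 2 to compound 3 is estimated as a number 23 percentage points higher from compound 2 to compound 3 (beyond the scatter). Compound 3 is expected to give about 48%, within 22% to 80%.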

Compound 3, a percentage reported as activity, at one concentration (the size of the read-out at that concentration, not a potency): 64%
Beside the measured number, compound 3's estimate is 16 percentage points below it; low and high end bracket the measured number.
By their numbers in this assay, from the lowest: compound 2; then compound 3; then compound 1.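

Among these compounds, this is the first pair here that differs in one place only, so the change can be read directly in this assay: hydrogen in place of trifluoromethyl on an aromatic carbon gives a number 39 percentage points higher from compound 2 to compound 3 (beyond the scatter). Because a higher number means a weaker effect, this position is not indifferent, and losing one trifluoromethyl group clearly weakens the effect at the concentration tested, even though the other trifluoromethyl group stays in place. No measurement shown here accounts for the size of this step.

Going by these compounds, it remains open whether trifluoromethyl is specifically needed on this carbon, or whether a different group could serve there. A nitrile or an amine at the same place would show whether the effect stays close to that of compound 2 or weakens towards that of compound 3.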